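Pyridin-3-yl for phenyl on the shared core: an estimate

The source may report more compounds than this note shows. Statements on the series, on what has been measured and on what is new or still open speak of the compounds shown alone.

Three compounds have been measured in an assay on cells for inhibition of sodium- and chloride-dependent glycine transporter 1 (Homo sapiens); a lower number here means that less compound is needed, a higher number that more compound is needed for the effect:

compound 1, `CSc1cc(C(F)(F)F)ccc1C(=O)NC1(c2ccccc2)CCCN(C)C1`, gives 67 nM
compound 2, `COc1cc(C(F)(F)F)cc(SC)c1C(=O)NC1(c2ccccc2)CCCN(C)C1`, gives 24 nM
compound 3, `COc1cc(C(F)(F)F)cc(SC)c1C(=O)N[C@]1(c2ccccc2)CCCN(C)C1`, gives 180 nM

Compound 2 stands lowest of the three. Adding a methoxy to the aromatic carbon brings the number down by a 2.8-fold lower number from compound 1 to compound 2 (0.45 log units; beyond the scatter). In the other direction the number rises by a 7.5-fold higher number from compound 2 to compound 3 (0.88 log units; beyond the scatter), and here the two structures differ only in the fact that one of compounds 2 and 3 is drawn with a defined configuration and the other without, at the place where they differ.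

Compound 4, `COc1cc(C(F)(F)F)cc(SC)c1C(=O)NC1(c2cccnc2)CCCN(C)C1`, is not yet measured. It differs from compound 2 by pyridin-3-yl in place of phenyl on a saturated ring carbon. Neither measured step touches this part of the molecule: one concerns a substituent on the aromatic ring of the amide side, the other a stereocentre drawn or not drawn. For the measured compounds named here, no measured step therefore bears directly on this change, and in this assay a step within the usual scatter, or at most a small rise, is expected. Compound 4 is estimated to give 45 nM, with a range from 12 nM to 160 nM. This estimate corresponds to an expected step of a 1.9-fold higher number from compound 2 to compound 4 (0.27 log units; within the scatter).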

Compound 4, half-maximal effective concentration: 54 nM
Estimate against measurement, compound 4: 1.2-fold (0.08 log units) below, within the range that was stated.
By their numbers in this assay, from the lowest: compound 2; then compounds 4 and 1 (each within the scatter of the next); then compound 3.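

In this assay, the saturated ring carbon that carries the aromatic ring had not been touched by any earlier step, and the exchange here gives a 2.3-fold higher number from compound 2 to compound 4 (0.35 log units; beyond the scatter). This shows that the number at this position does respond to the aromatic ring it carries: replacing one ring carbon with nitrogen, which adds one hydrogen-bond acceptor, produces a modest rise beyond the scatter. For the compounds shown here, the one piece of supporting information available concerns the drawn configuration of compounds 2 and 3 and offers no explanation for this step.

The compounds shown leave open whether another placement of the ring nitrogen, or a phenyl bearing a chlorine or an amine at this position, would give a similar number. Going by these compounds, compound 4 is also drawn without a configuration at this carbon, so how its single stereoisomers compare remains unknown.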